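A new side group and what to expect

This account rests on a few compounds, and the source may have more. Where it says the series, first, only, none or still open, it means among the compounds named here.

- compound 1 `O=C(NCc1cc(Cl)ccc1-n1cnnn1)[C@@H]1C[C@@H]2C[C@@H]2N1C(=O)[C@H](O)C1CCCCC1` gives 600 nM
- compound 2 `CC(C)(C)[C@@H](O)C(=O)N1[C@H](C(=O)NCc2cc(Cl)ccc2-n2cnnn2)C[C@@H]2C[C@@H]21` gives 1500 nM
- compound 3 `O=C(NCc1cc(Cl)ccc1-n1cnnn1)[C@@H]1C[C@@H]2C[C@@H]2N1C(=O)[C@H](O)Cc1ccccn1` gives 1000 nM

These three share one core and differ only in the group on a saturated chain carbon bound to a carbonyl carbon and an oxygen on a saturated carbon. In a functional assay on a cell-free system (plasma, Homo sapiens), with a stated time of 3 min (on this read-out lower numbers stand for stronger inhibition and higher numbers for weaker inhibition), compound 3 cannot be told apart from either of the others (a 1.7-fold higher number from compound 1 to compound 3 (0.22 log units; within the scatter)) and (a 1.5-fold lower number from compound 2 to compound 3 (0.18 log units; within the scatter)). Compound 4 `COC(C)(C)[C@@H](O)C(=O)N1[C@H](C(=O)NCc2cc(Cl)ccc2-n2cnnn2)C[C@@H]2C[C@@H]21` carries 1-methoxy-1-methylethyl in place of (pyridin-2-yl)methyl (1-methoxy-1-methylethyl in place of (pyridin-2-yl)methyl on a saturated chain carbon bound to a carbonyl carbon and an oxygen on a saturated carbon). Within the data shown here, only one measured swap at this place exceeds the scatter, and only modestly (a 2.5-fold higher number from compound 1 to compound 2 (0.40 log units; beyond the scatter)). Among the measured compounds shown here, no measured compound carries the entering group, so these steps guide only loosely. In this assay the expected step stays within the scatter (a 1.2-fold higher number from compound 3 to compound 4 (0.08 log units; within the scatter)) in this estimate. Compound 4 is estimated at 1200 nM with an expected range from 450 nM to 3000 nM for the measurement.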

Compound 4, half-maximal inhibitory concentration: 1000 nM
Beside the measured number, compound 4's estimate is 1.2-fold (0.08 log units) above it; the measured number falls inside the stated range.
By their numbers in this assay, from the lowest: compounds 1, 3, 4 and 2 (each within the scatter of the next, the first and the last beyond it).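

In this assay, the open-chain 1-methoxy-1-methylethyl group can stand in for the ring-bearing (pyridin-2-yl)methyl group, with no change at the digits printed from compound 3 to compound 4 (within the scatter) as the step. Methoxy in place of one methyl of the tert-butyl group gives a 1.5-fold lower number from compound 2 to compound 4 (0.18 log units; within the scatter) and the comparison with the cyclohexyl group gives a 1.7-fold higher number from compound 1 to compound 4 (0.22 log units; within the scatter) so this entering group cannot be told apart from any of the other three. Nothing measured here explains this flat response.

As far as these compounds go, whether an amine, a carboxylic acid or a longer chain at this place would give a step beyond the scatter remains open.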